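The compounds below may be only part of what the source reports. "The series", "measured", "known", "first", "only" and "open" are said of these compounds alone.

Working notes on the series. Within the data shown here, compound 1 `N=C(N)NCCCCCCC(=O)NCC(=O)NCCCCNCCCN` and compound 2 `N=C(N)NCCCC[C@H](O)CC(=O)N[C@@H](O)CNCCCCNCCCN` are the two compounds measured so far in a physicochemical assay for pharmacokinetics, at pH 5; a higher number here means that the compound lasts longer, a lower number that the compound disappears faster. Compound 1 gives 90 h in this assay, the lower of the two figures in hand, while compound 2 gives 120 h; the gap is within the scatter, so no order between them is established. Among the measured compounds shown here, no step between measured compounds that differ in a single place is available. Compound 3 `COC(NC(=O)CCCCCCNC(=N)N)C(=O)NCCCCNCCCN` has not yet been measured in this assay. It differs from compound 1 by methoxy in place of hydrogen on a saturated chain carbon bound to an amide-type nitrogen and a carbonyl carbon. Nothing measured speaks directly to this change, and compound 2 differs from compound 1 in more than one place, so its value can only be noted. Compound 3 is expected to show a moderate loss, a 1.8-fold lower number from compound 1 to compound 3 (0.26 log units; within the scatter), somewhat beyond the scatter. The estimate for compound 3 in this assay is 50 h, with a range from 15 h to 150 h.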

Compound 3, half-life: 140 h
Compound 3: the middle estimate sits 2.8-fold (0.45 log units) below what was measured; the range from low to high includes it.
By their numbers in this assay, from the lowest: compounds 1, 2 and 3 (each within the scatter of the next).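

In this assay, this position now has its first single-place reading: methoxy in place of hydrogen on a saturated chain carbon bound to an amide-type nitrogen and a carbonyl carbon gives a 1.6-fold higher number from compound 1 to compound 3 (0.19 log units; within the scatter) and so leaves no difference that can be told from the scatter. The earlier compounds shown here could not show this, since compound 1 and compound 2 differ in more than one place. Nothing at hand bears on why the methoxy change reads this way.

As far as these compounds go, whether ethoxy or fluorine on this same carbon would give a difference beyond the scatter in this assay remains open. From the compounds shown here alone, it also remains open whether methoxy at this carbon would read the same on a chain carrying the hydroxy groups of compound 2.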